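The source may report more compounds than this note shows. Statements on the series, on what has been measured and on what is new or still open speak of the compounds shown alone.

In a functional assay on U-87MG ATCC cells (Homo sapiens) for antiproliferative activity, with a stated time of 3 days (a higher number here means that more compound is needed for the effect, a lower number that less compound is needed), compound 1 (`Cc1ccc(CNCc2ccc(O)c3ncccc23)cc1`) gives > 10 uM, a limit of the assay and not a number. Compound 2 (`Oc1ccc(CNCc2ccc(C(F)(F)F)cc2)c2cccnc12`) gives > 10 uM, also only a limit. Going by the values given here, the single measured step, a step that the two limits leave unreadable from compound 1 to compound 2, therefore has no readable size, and the limit of > 10 uM in this assay, at which 2 of the 2 values shown sit, is all that the evidence offers. Compound 3 (`Oc1ccc(CN(Cc2ccc(C(F)(F)F)cc2)Cc2cccc3ncccc23)c2cccnc12`) has (quinolin-5-yl)methyl in place of hydrogen on an amine nitrogen. Among the compounds with values here, no measured step tests this change, so the expectation is weak: a modest move towards a lower number in this assay. The expected step is an at least 1.2-fold lower number from compound 2 to compound 3 (0.09 log units; that floor lies within the scatter). Compound 3 is estimated at 8 uM, with an expected range of 2.5 uM to 25 uM.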

Compound 3, concentration for half-maximal effect: > 10 uM
Compound 3: a limit, no number; the forecaster's own chance of this, stated with the estimate: 45%; middle value at least 1.2-fold (0.09 log units) away from the limit.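

In this assay compound 3 gives > 10 uM, again a limit of the assay and not a number, so the step from compound 2 to compound 3 cannot be read. The compounds shown leave open whether compound 1, compound 2 and compound 3 differ at all in this assay.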